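This account rests on a few compounds, and the source may have more. Where it says the series, first, only, none or still open, it means among the compounds named here.

Measured so far in an in vitro ADME assay on microsomes from Gut (Homo sapiens) for metabolic stability, in the presence of a further agent that is not named here; on this read-out lower numbers stand for slow clearance and higher numbers for fast clearance:
- compound 1 `COc1ccc(OC(F)(F)F)cc1Cn1c(C(=O)NCC(C)(C)CO)cc2cc(C#N)ccc21`: 68 mL.min-1.g-1
- compound 2 `COc1ccc(Br)cc1Cn1c(C(=O)NCC(C)(C)CO)cc2cc(C#N)ccc21`: 94 mL.min-1.g-1

Going by the values given here, compound 2 stands within the scatter of compound 1, its only measured neighbour. Compound 3 `COc1ccc(C)cc1Cn1c(C(=O)NCC(C)(C)CO)cc2cc(C#N)ccc21` differs from compound 2 at one place: methyl in place of bromo on an aromatic carbon. Among the compounds with values here, the only measured step at that carbon is a 1.4-fold higher number from compound 1 to compound 2 (0.14 log units; within the scatter), which stays within the scatter. Within the data shown here, no measured compound carries a methyl there, so the evidence is indirect. In this assay, no change beyond the scatter is expected. The expected step is a 1.1-fold lower number from compound 2 to compound 3 (0.04 log units; within the scatter). The estimate for compound 3 is 85 mL.min-1.g-1, with an expected range of 45 mL.min-1.g-1 to 150 mL.min-1.g-1.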

Compound 3, intrinsic clearance in microsomes: 64 mL.min-1.g-1
Compound 3: the middle estimate sits 1.3-fold (0.12 log units) above what was measured; measured number inside the range.
By their numbers in this assay, from the lowest: compounds 3, 1 and 2 (each within the scatter of the next).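

Methyl in place of bromo, on the aromatic carbon para to a methoxy group, gives a 1.5-fold lower number from compound 2 to compound 3 (0.17 log units; within the scatter) in this assay and methyl in place of trifluoromethoxy gives a 1.1-fold lower number from compound 1 to compound 3 (0.03 log units; within the scatter) at that same carbon. Bromo, trifluoromethoxy and methyl are therefore not separated at this position, and all steps among them lie within the scatter. Nothing at hand explains these numbers.

From the compounds shown here alone, whether an amine or a carboxylic acid on this carbon would give a step beyond the scatter stays open. The same question stands for a longer chain there.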